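Replacing an Acyl Amide by an Aryl Amine on a Shared Core

A few compounds are considered here, and "the series" means these few. Any claim that something is new, unique, unknown or untested is made for them only; others in the source may bear on it.

Compound 1 `N#Cc1ccc(C(=O)Nc2ccc3nc(NC(=O)C4CCCCC4)sc3c2)cc1` gives 3.3 ug/mL.
Compound 2 `Cc1nc(C)c(C(=O)Nc2ccc3nc(NC(=O)C4CCCCC4)sc3c2)s1` gives 0.39 ug/mL.
Compound 3 `O=C(Nc1ccc2nc(NC(=O)C3CC3)sc2c1)c1c(Cl)cccc1Cl` gives 0.013 ug/mL.

All three were tested in a functional assay on WI-38 VA13 cells (Homo sapiens) for cytotoxicity; on this read-out lower numbers stand for an effect already at smaller amounts and higher numbers for an effect only at larger amounts of compound. Compound 3 stands at the lowest number of the three, well beyond the scatter from both others; compound 2 sits nearest, compound 1 furthest. Compound 4 `COc1cccc(Nc2nc3ccc(NC(=O)c4c(Cl)cccc4Cl)cc3s2)c1` differs from compound 3 in one place: 3-methoxyphenyl in place of cyclopropylcarbonyl on a nitrogen on an aromatic ring. Among the compounds with values here, the only measured step, an 8.5-fold lower number from compound 1 to compound 2 (0.93 log units; beyond the scatter), concerns the other amide of the core, not the nitrogen on the aromatic ring, so it offers no direct guide to this change. With nothing measured at that position, a large move in either direction cannot be ruled out; a higher number is expected for compound 4, a step of a 12-fold higher number from compound 3 to compound 4 (1.06 log units; beyond the scatter), giving an estimate of 0.15 ug/mL with a range from 0.015 ug/mL to 1.5 ug/mL.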

Compound 4, half-maximal effective concentration: > 7.2 ug/mL
Compound 4: a limit, no number; the forecaster's own chance of this, stated with the estimate: 5%; middle value at least 48-fold (1.68 log units) away from the limit.
By their numbers in this assay, from the lowest: compound 3; then compound 2; then compound 1. At a limit, above all of these: compound 4.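

In this assay, 3-methoxyphenyl in place of cyclopropylcarbonyl on this nitrogen gives an at least 550-fold higher number from compound 3 to compound 4 (2.74 log units; beyond the scatter), a large move. The group on this nitrogen therefore matters strongly here, which the earlier step at the other end of the core could not show. The reading for compound 4 is a limit of the assay and not a number: the limit of > 7.2 ug/mL in this assay, at which 1 of the 4 values shown sits.

One replacement cannot say whether the loss of the carbonyl or the methoxy-bearing ring carries this step. A plain phenyl or an unsubstituted amine on this nitrogen would help separate the two.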